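The source may hold more compounds than are shown below. What is called first, only, known or untested is meant among the compounds shown, and "the series" means these compounds.

Measured so far, in a physicochemical assay on A549 cells for solubility, read by microscopy, with a stated time of 24 h; a higher number here means a weaker inhibitor, a lower number a stronger inhibitor:

- compound 1 `O=C(N/N=C/c1ccco1)c1cc(-c2ccccc2)nn1Cc1ccc(Cl)nc1`: compound 1 gives 19400 nM
- compound 2 `O=C(N/N=C/c1ccco1)c1cc(-c2ccc(Cl)cc2)nn1Cc1ccc(Cl)nc1`: compound 2 gives 9820 nM
- compound 3 `O=C(N/N=C/c1ccccc1O)c1cc(-c2ccccc2)nn1Cc1ccccc1`: compound 3 gives 650 nM

Compound 2 differs from compound 1 in one place, (chloro in place of hydrogen on an aromatic carbon). That change gave a 2.0-fold lower number from compound 1 to compound 2 (0.30 log units; within the scatter). Compound 3 has a different core, and the difference between the two cores is not broken down here. Compound 3 stands with the lowest number of the three; the gap to compound 2 and the gap to compound 1 are each beyond the scatter.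

Compound 4 `O=C(N/N=C/c1ccccc1O)c1cc(-c2ccc(Cl)cc2)nn1Cc1ccccc1` is not yet measured. It differs from compound 3 by chloro in place of hydrogen on an aromatic carbon. Within the data shown here, this is the same change as the one from compound 1 to compound 2: both act on an aromatic carbon of a six-membered aromatic ring of carbon only, para to a large group, and the wider reading is the same, phenyl to 4-chlorophenyl. Among the measured compounds shown here, the only precedent for the change is a 2.0-fold lower number from compound 1 to compound 2 (0.30 log units; within the scatter), a step that lies within the scatter, and it was seen on the core of compound 1, not on the core of compound 3. For the measured compounds named here, there is no second example that would show whether the change behaves alike on both cores.

The step from compound 3 to compound 4 is therefore expected to be small, a 1.5-fold lower number from compound 3 to compound 4 (0.19 log units; within the scatter), resting on a 2.0-fold lower number from compound 1 to compound 2 (0.30 log units; within the scatter). Compound 4 is expected to give 420 nM in this assay, with a likely range from 150 nM to 1300 nM.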

Compound 4, half-maximal inhibitory concentration: 680 nM
Compound 4: middle estimate off by 1.6-fold (0.21 log units), on the low side; the measured number falls inside the stated range.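

In this assay, phenyl to 4-chlorophenyl on the core of compound 3 gives a 1.0-fold higher number from compound 3 to compound 4 (0.02 log units; within the scatter), and the same change on the core of compound 1 gives a 2.0-fold lower number from compound 1 to compound 2 (0.30 log units; within the scatter), so on both cores shown, the chloro compound cannot be told apart from its hydrogen partner. Among these compounds, this supports carrying the change between these two cores with no more than a step within the scatter expected, but it rests on a single pair per core and does not establish how the change would behave on any other core, nor does it show a real difference or a real likeness in size between the two steps beyond what the scatter allows. No measurement at hand bears on why the change behaves this way on either core.

Still open, going by these compounds, is whether a different group on the same aromatic carbon, para to a large group, such as an amine, a carboxylic acid, a methoxy group or a longer chain, would give a step beyond the scatter on either core. Also open is which of the places separating the two cores matters in this assay, since no pair shown differs in only one of them.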